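Para substituent on the aryl ring: methoxy to chloro

The source may hold more compounds than are shown below. What is called first, only, known or untested is meant among the compounds shown, and "the series" means these compounds.

Among the compounds with values here, compound 2 `CCOC(=O)c1c(-c2ccc(OC)cc2)c(C#N)c(=O)n(/N=C(\C)c2ccc(NS(=O)(=O)c3ccc(Cl)cc3)cc2)c1N` gives 61700 nM in a functional assay on HepG2 cells (Homo sapiens) for cytotoxicity, read by sulforhodamine B assay, with a stated time of 48 h (a lower number here means a stronger inhibitor, a higher number a weaker inhibitor), the highest of the two numbers so far; the nearest is compound 1 `CCOC(=O)c1c(-c2ccc(C)cc2)c(C#N)c(=O)n(/N=C(\C)c2ccc(NS(=O)(=O)c3ccc(Cl)cc3)cc2)c1N` with 8380 nM. Compound 3 `CCOC(=O)c1c(-c2ccc(Cl)cc2)c(C#N)c(=O)n(/N=C(\C)c2ccc(NS(=O)(=O)c3ccc(Cl)cc3)cc2)c1N` carries chloro in place of methoxy on an aromatic carbon. Within the data shown here, the only step that bears on this position is a 7.4-fold higher number from compound 1 to compound 2 (0.87 log units; beyond the scatter); no step involving chloro has been measured. The change to chloro is expected to give a lower number, estimated as a 4.1-fold lower number from compound 2 to compound 3 (0.61 log units; beyond the scatter), with wide uncertainty since only compound 1 and compound 2 inform it. Compound 3 is therefore estimated at 15000 nM, range 5000 nM to 45000 nM.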

Compound 3, half-maximal inhibitory concentration: 20200 nM
Compound 3: the middle estimate sits 1.3-fold (0.13 log units) below what was measured; the range from low to high includes it.
By their numbers in this assay, from the lowest: compound 1; then compound 3; then compound 2.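

In this assay, the change from 4-methoxyphenyl to 4-chlorophenyl recovers only part of the ground lost with methoxy, giving a 3.1-fold lower number from compound 2 to compound 3 (0.48 log units; beyond the scatter) but still a 2.4-fold higher number from compound 1 to compound 3 (0.38 log units; beyond the scatter). This position therefore separates all three groups, with methyl giving the lowest number and chloro falling between methyl and methoxy. Nothing available explains this order.

Still open, on these data alone, is whether an unsubstituted phenyl, an amine or a carboxylic acid at this position would fall inside this span. Whether the same order holds with other changes elsewhere on the shared core is also unresolved.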